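The compounds below may be only part of what the source reports. "The series", "measured", "known", "first", "only" and "open" are said of these compounds alone.

Compound 1 `CCOC(=O)C1(Cc2ccccc2)CN(c2ccccc2)Cc2nnn(Cc3ccccc3)c21` is the starting point. In an ADME assay on HEL cells (Homo sapiens) for cytotoxicity, read by microscopy, with a stated time of 3 days (a higher number here means that more compound is tolerated, a lower number that less compound is tolerated), compound 1 gives >= 20000 nM, and this is a limit of the assay, not a measured number. Compound 2 `CCOC(=O)C1(Cc2ccccc2)CN(c2ccccc2)Cc2nnn(Cc3ccc(OC)cc3)c21` carries methoxy in place of hydrogen on an aromatic carbon. In this assay compound 2 gives > 100000 nM, again a limit of the assay. Compound 3 `CCOC(=O)C1(Cc2ccccc2)CN(c2ccccc2)Cc2nnn(Cc3ccco3)c21` carries furan-2-yl in place of phenyl on a saturated chain carbon bound to an aromatic nitrogen, and in this assay compound 3 gives 100000 nM. The steps a step that the two limits leave unreadable from compound 1 to compound 2 and a step that the limit leaves unreadable from compound 1 to compound 3 cannot be sized because of the limit of >= 20000 nM in this assay, at which 1 of the 3 values shown sits, and (the limit of > 100000 nM in this assay, at which 1 of the 3 values shown sits), and a number no higher from compound 2 to compound 3 (the limit leaves the size open) is likewise left open. Compound 4 `CCCCCCCCn1nnc2c1C(Cc1ccccc1)(C(=O)OCC)CN(c1ccccc1)C2` differs from compound 1 by heptyl in place of phenyl on a saturated chain carbon bound to an aromatic nitrogen. For the measured compounds named here, no measured step swaps a ring for a chain at this place, so nothing comparable exists. Compound 4 is therefore expected to fall where all three measured compounds sit, at 50000 nM, between 15000 nM and 150000 nM, which would mean an expected step that the limit leaves unreadable from compound 1 to compound 4 that may well again be only a limit.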

Compound 4, minimum cytotoxic concentration: >= 20000 nM
Compound 4: only a limit was reported; the forecaster's own chance of this, stated with the estimate: 60%; the middle value is on the limit's open side.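

For the compounds shown here, the result for compound 4 in this assay is only a limit, so no step between it and compound 1, compound 2 or compound 3 can be read: the limit of >= 20000 nM in this assay, at which 2 of the 4 values shown sit. The compounds shown leave open whether heptyl in place of phenyl changes how much compound the cells tolerate.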